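This account rests on a few compounds, and the source may have more. Where it says the series, first, only, none or still open, it means among the compounds named here.

Measured in a functional assay on TOV112D cells (Homo sapiens) for antiproliferative activity, read by CellTiter-Glo, with a stated time of 96 h; on this read-out higher numbers stand for weaker inhibition and lower numbers for stronger inhibition:
- Compound 1 `COc1ccc(-c2nsc3c2NC(=O)CC3c2cccc(OC)c2)cc1`: 808 nM
- Compound 2 `COc1ccc(-c2nsc3c2NC(=O)CC3c2ccc3c(c2)OCCO3)cc1`: 659 nM

Compound 1 has the top number of this small pair, but the gap to compound 2 lies within the scatter, so the two cannot be ranked. Compound 3 `COc1ccc(-c2nsc3c2NC(=O)CC3c2cccc(F)c2)cc1` keeps the core of compound 1 and makes one change: fluoro in place of methoxy on an aromatic carbon. In words, this is fluoro in place of methoxy on an aromatic carbon, meta to a large group. Among the compounds with values here, no measured pair differs by a single change, so the data give no direct guide to this swap. As far as these compounds go, with no evidence for a large effect, no step beyond the scatter is expected in this assay, and the direction remains open. The estimated step is a 1.2-fold higher number from compound 1 to compound 3 (0.09 log units; within the scatter). The value expected for compound 3 is 1000 nM, with an estimated range of 400 nM to 2500 nM.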

Compound 3, half-maximal inhibitory concentration: > 2000 nM
Compound 3 ended at the assay's limit; the forecaster's own chance of this, stated with the estimate: 3%; middle value at least 2.0-fold (0.30 log units) away from the limit.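

Within the data shown here, this is the first single change with a readable effect. Among these compounds, on an aromatic carbon, meta to a large group, putting fluoro in place of methoxy gives an at least 2.4-fold higher number from compound 1 to compound 3 (0.39 log units; beyond the scatter) in this assay, so activity in these cells depends on what sits at this position, which the earlier compounds, with no single-change step between them, could not show. Compound 3 stands at > 2000 nM, which is a limit of the assay and not a number, and the full size of the step stays unknown because the reading ends there: the limit of > 2000 nM in this assay, at which 1 of the 3 values shown sits.

This one pair cannot tell whether the loss comes from removing methoxy or from introducing fluoro. It also leaves open whether a hydroxy group, a chloro group or a longer ethoxy chain at this position would keep the activity of compound 1.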